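Carbamoyl in Place of Cyclopentylmethyl on the Shared Core

The compounds below may be only part of what the source reports. "The series", "measured", "known", "first", "only" and "open" are said of these compounds alone.

Measured compounds:
compound 1 `CCCCCNc1nc(N)nc2ccccc12`: 0.1 uM
compound 2 `CCCCNc1nc(N)nc2cccc(CC3CCCC3)c12`: > 25 uM

Of the compounds shown here, two have been measured in an ADME assay on HEK293 cells for agonist activity at Toll-like receptor 8 (Homo sapiens), read by a luciferase reporter, with a stated time of 6 h; a higher number here means that more compound is needed for the effect, a lower number that less compound is needed. Compound 1 `CCCCCNc1nc(N)nc2ccccc12` gives 0.1 uM. Compound 2 `CCCCNc1nc(N)nc2cccc(CC3CCCC3)c12` reaches only the limit of the assay, > 25 uM, and no number is known for it; (the limit of > 25 uM in this assay, at which 1 of the 2 values shown sits). Compound 3 `CCCCNc1nc(N)nc2cccc(C(=O)N(C)C(C)C)c12` has not yet been measured; it differs from compound 2 by isopropyl(methyl)carbamoyl in place of cyclopentylmethyl on an aromatic carbon. Going by the values given here, no step between measured compounds is available, and compound 2 stands at a limit, so the size of the change from compound 2 to compound 3 cannot be read from the numbers. The author expects the step of an at least 5.0-fold lower number from compound 2 to compound 3 (0.69 log units; beyond the scatter) to run toward less compound being needed, though the limit for compound 2 leaves the size uncertain. Compound 3 is estimated at 5 uM, with a range from 0.5 uM to 25 uM.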

Compound 3, minimum effective concentration: > 25 uM
Compound 3: no number, only a limit; the forecaster's own chance of this, stated with the estimate: 40%; at least 5.0-fold (0.69 log units) between middle value and limit.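

Compound 3 gives only a limit, > 25 uM, and no number. Compound 2 also stands at a limit, so no step between compound 2 and compound 3 can be read: the limit of > 25 uM in this assay, at which 2 of the 3 values shown sit.

The compounds shown leave open whether isopropyl(methyl)carbamoyl or cyclopentylmethyl requires more compound for the effect.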